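Trimming the Amide on a Bis-sulfonamide Piperidine Core

The source may hold more compounds than are shown below. What is called first, only, known or untested is meant among the compounds shown, and "the series" means these compounds.

Of the compounds shown here, two sharing one core have been measured so far. Compound 1 `CCN(CC)C(=O)[C@@H]1CCCN(S(=O)(=O)c2ccc(S(=O)(=O)N(CC)CC)cc2)C1` gives 700 nM in a functional assay on MIA PaCa-2 cells (Homo sapiens) for inhibition, read by MTT assay, with a stated time of 3 days (on this read-out higher numbers stand for weaker inhibition and lower numbers for stronger inhibition), the highest of the two numbers. Compound 2 `CC(C)c1noc(N2CCN(C(=O)[C@@H]3CCCN(S(=O)(=O)c4ccc(S(=O)(=O)NC(C)(C)C)cc4)C3)CC2)n1` gives 100 nM in this assay, and that gap lies beyond the usual scatter. Compound 3 `CCN(CC)S(=O)(=O)c1ccc(S(=O)(=O)N2CCC[C@@H](C(=O)NC)C2)cc1` has not yet been measured. It differs from compound 1 in a single place: methylamino in place of diethylamino on a carbonyl carbon. Within the data shown here, no measured pair in this set shows that exact change, so the expectation rests on compound 1 alone; compound 2 differs from it in several places at once and offers no direct guide. The change removes a diethylamino group and brings in a methylamino group with one hydrogen-bond donor; a modest weakening is expected, of the size a 2.1-fold higher number from compound 1 to compound 3 (0.33 log units; beyond the scatter), though a result within the scatter would not surprise. Compound 3 is therefore estimated at 1500 nM, with a likely range from 400 nM to 6000 nM.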

Compound 3, half-maximal inhibitory concentration: 2000 nM
The estimate for compound 3 lay 1.3-fold (0.12 log units) below the measured number; low and high end bracket the measured number.
By their numbers in this assay, from the lowest: compound 2; then compound 1; then compound 3.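

Replacing diethylamino with methylamino on a carbonyl carbon gives a 2.9-fold higher number from compound 1 to compound 3 (0.46 log units; beyond the scatter) in this assay. Higher numbers mean weaker inhibition here, so this is a loss of activity. Among these compounds, this is the first direct sign that the group on this carbonyl carbon affects the read-out while the rest of the molecule stays fixed. The step swaps the diethylamino group for a smaller group and adds a hydrogen-bond donor in a single move, and nothing measured here explains the change.

A dimethylamino or ethylamino group on the same carbonyl carbon would help separate the loss of the carbon atoms from the gain of the amide hydrogen. As far as these compounds go, compound 2 differs from compound 1 in several places at once, so how much its amide portion contributes to its lower number remains open.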